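This account rests on a few compounds, and the source may have more. Where it says the series, first, only, none or still open, it means among the compounds named here.

Measured in a toxicity assay on MDCK cells (Canis lupus familiaris) for cytotoxicity, read by CCK-8 assay, with a stated time of 48 h; on this read-out lower numbers stand for higher toxicity in this test and higher numbers for lower toxicity in this test:
Compound 1 `CCOc1ccc(C(=O)NNc2c(Br)cccc2Br)cc1`: > 100000 nM
Compound 2 `CN(C)c1ccc(C(=O)NNc2c(Br)cc(Br)cc2Br)cc1`: 20300 nM

The reading for compound 1 is a limit of the assay, not a number. Within the data shown here, compound 2, at 20300 nM, therefore holds the only true number in this small set. Among the measured compounds shown here, no measured pair differs in one place only, so the size of the coming change has no direct precedent.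

Compound 3 `CN(C)c1ccc(C(=O)NNc2c(Br)cccc2Br)cc1` is derived from compound 2 with hydrogen in place of bromo on an aromatic carbon, meta to two bromo groups and para to a large group (hydrogen in place of bromo on an aromatic carbon). It keeps the bromo pattern of compound 1, whose > 100000 nM is a limit. A moderate rise in this assay, beyond the usual scatter, is therefore expected, and the estimated change is a 3.0-fold higher number from compound 2 to compound 3 (0.47 log units; beyond the scatter). Compound 3 is estimated at 60000 nM, with an expected range from 25000 nM to 100000 nM.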

Compound 3, half-maximal cytotoxic concentration: > 100000 nM
Compound 3: only a limit was reported; the forecaster's own chance of this, stated with the estimate: 40%; middle value at least 1.6-fold (0.22 log units) away from the limit.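

In this assay, among these compounds, hydrogen in place of bromo on the aromatic carbon, meta to two bromo groups and para to a large group, gives an at least 4.9-fold higher number from compound 2 to compound 3 (0.69 log units; beyond the scatter), the first single change in this set whose size can be read. On these data alone, the reading for compound 3 is a limit, so this size is only a lowest bound and the full effect of this one bromo group stays unknown. With that bromo group gone, compound 3 sits at the same ceiling as compound 1: the limit of > 100000 nM in this assay, at which 2 of the 3 values shown sit.

As far as these compounds go, the step from compound 1 to compound 3, dimethylamino in place of ethoxy, cannot be read, and so whether these two groups differ in this test stays open. Also open is how chloro or methyl at this same carbon would read, neither of which is among the compounds shown.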